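The source may hold more compounds than are shown below. What is called first, only, known or untested is meant among the compounds shown, and "the series" means these compounds.

Two compounds define the ground here. Compound 1, `COc1ccc(F)cc1-c1cccc(-c2nn(CCCC#N)c(=O)o2)c1`, in a functional assay on the whole organism (strain Wistar albino) for inhibition, with Rattus norvegicus as the target, read by paw edema, with stated times of 30 min and 1.5 h, at a dose of 10 mg/kg by the oral route (a higher number here means more inhibition at the dose given (going by the name of the read-out), a lower number less inhibition), gives 59%. Going by the values given here, compound 2, `COc1ccc(F)cc1-c1cccc(-c2nn(CCOC3CCCCO3)c(=O)o2)c1`, in this assay gives 44%, which is the lower of the two numbers seen; the only step measured, a number 15 percentage points lower from compound 1 to compound 2 (beyond the scatter), lies beyond the scatter and is modest in size. Compound 3, `COC(=O)CCCn1nc(-c2cccc(-c3cc(F)ccc3OC)c2)oc1=O`, has not yet been measured. It differs from compound 2 as follows: (methoxycarbonyl)methyl in place of (oxan-2-yl)oxy on a saturated chain carbon, two bonds along the chain from an aromatic nitrogen. Among the compounds with values here, only the step from compound 1 to compound 2 bears on this change, since it also exchanges the group on the same saturated chain carbon two bonds from the aromatic nitrogen, and there the larger ring-bearing group went with the lower number. The incoming (methoxycarbonyl)methyl is, like cyanomethyl, a short open chain, so in this assay the step expected is a number 8 percentage points higher from compound 2 to compound 3 (within the scatter). Compound 3 is therefore estimated at 52% in this assay, within a range from 38% to 66%.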

Compound 3, a percentage reported as inhibition, in the whole organism at one dose (the size of the read-out at that dose, not a potency): 61%
Compound 3: the middle estimate sits 9 percentage points below what was measured; the measured number falls inside the stated range.
By their numbers in this assay, from the lowest: compound 2; then compounds 1 and 3 (each within the scatter of the next).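

In this assay, (methoxycarbonyl)methyl in place of (oxan-2-yl)oxy on a saturated chain carbon, two bonds along the chain from an aromatic nitrogen, gives a number 17 percentage points higher from compound 2 to compound 3 (beyond the scatter) and so shows that this position can move in the upward direction as well, with a second open-chain group standing clear of the ring-bearing one. Methoxycarbonyl in place of cyano on a saturated chain carbon, three bonds along the chain from an aromatic nitrogen, gives a number 2 percentage points higher from compound 1 to compound 3 (within the scatter), so the two open-chain ends cannot be told apart here, and among the three compounds only compound 2, with its six-membered non-aromatic ring, stands apart. Nothing given here accounts for these differences.

From the compounds shown here alone, whether the ring itself or the rest of the (oxan-2-yl)oxy group goes with the lower number stays open, and a plain methoxy group on the same chain would separate the two. Also open, going by these compounds, is how a carboxylic acid, an amine or a longer chain at this end would read at this single dose.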